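The source may hold more compounds than are shown below. What is called first, only, known or untested is meant among the compounds shown, and "the series" means these compounds.

Compounds with measured values:
compound 1 `Cc1cccc(C(=O)NCN2CCC(c3ccccn3)CC2)c1`: 9 nM
compound 2 `Cc1ccc([N+](=O)[O-])cc1NC(=O)CN1CCC(c2cccc[n+]2[O-])CC1`: 134 nM
compound 3 `CCc1cccc(C)c1NC(=O)CN1CCC(c2ccccn2)CC1`: 111 nM

In a functional assay on HEK293 cells for agonist activity at D(4) dopamine receptor (Homo sapiens), read by FLIPR (a higher number here means that more compound is needed for the effect, a lower number that less compound is needed), compound 1 gives 9 nM, the lowest of the three numbers. Compound 3 gives 111 nM and compound 2 gives 134 nM, and both of these stand beyond the scatter above compound 1.

Compound 4 `COc1ccccc1C1CCN(CNC(=O)c2cccc(C)c2)CC1` has not yet been measured. Compared with compound 1 it differs in one place: 2-methoxyphenyl in place of pyridin-2-yl on a saturated ring carbon. Among the compounds with values here, no measured pair here shows what such an exchange does, so the expectation rests on compound 1 alone. The step is expected to be small, with the number for compound 4 somewhat higher than that of compound 1, as a 2.2-fold higher number from compound 1 to compound 4 (0.35 log units; beyond the scatter) expresses. Compound 4 is therefore estimated at 20 nM, with a range from 5 nM to 80 nM.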

Compound 4, half-maximal effective concentration: 206 nM
The estimate for compound 4 lay 10-fold (1.01 log units) below the measured number; measured number above the stated range.
By their numbers in this assay, from the lowest: compound 1; then compounds 3, 2 and 4 (each within the scatter of the next).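

In this assay, putting 2-methoxyphenyl in place of pyridin-2-yl on the saturated ring carbon gives a 23-fold higher number from compound 1 to compound 4 (1.36 log units; beyond the scatter), a large step. Within the data shown here, this is the first measured step at this position, and it shows that the number here responds strongly to the group on that ring carbon. The compounds shown leave open whether the step goes with the loss of the ring nitrogen or with the arrival of the methoxy group, and a plain phenyl group would separate the two. No other measurement at hand bears on the reason for the step.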